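The compounds below may be only part of what the source reports. "The series", "measured", "known", "first", "only" and "open" are said of these compounds alone.

Among the compounds with values here, the three compounds measured so far share one core and differ only in the group on the carbonyl carbon attached to the ring nitrogen. Compound 1 `O=C(NC[C@@H]1[C@H]2CN(C(=O)OCc3cc(Cl)cc(Cl)c3)C[C@@H]12)c1ccc2[nH]c(=O)oc2c1` carries a (3,5-dichlorobenzyl)oxy group there. In a physicochemical assay for solubility, with a stated time of 24 h, at pH 6.8 (a higher number here means a more soluble compound, a lower number a less soluble compound), compound 1 gives < 1 ug/mL, which is a limit of the assay and not a number. Compound 2 `O=C(NC[C@@H]1[C@H]2CN(C(=O)/C=C/c3cc(Cl)cc(Cl)c3)C[C@@H]12)c1ccc2[nH]c(=O)oc2c1` has a 2-(3,5-dichlorophenyl)ethenyl group in that place. In this assay compound 2 gives < 1 ug/mL, again only a limit. Compound 3 `O=C(NC[C@@H]1[C@H]2CN(C(=O)CCc3cc(Cl)cc(Cl)c3)C[C@@H]12)c1ccc2[nH]c(=O)oc2c1` carries a 2-(3,5-dichlorophenyl)ethyl group. In this assay compound 3 gives < 1 ug/mL, also a limit. The steps a step that the two limits leave unreadable from compound 1 to compound 2, a step that the two limits leave unreadable from compound 1 to compound 3 and a step that the two limits leave unreadable from compound 2 to compound 3 cannot be sized because of the limit of < 1 ug/mL in this assay, at which 3 of the 3 values shown sit. Compound 4 `CC(OC(=O)N1C[C@@H]2[C@@H](CNC(=O)c3ccc4[nH]c(=O)oc4c3)[C@@H]2C1)c1cc(Cl)cc(Cl)c1` differs from compound 3 in one place: a group of 11 heavy atoms (8 carbon, 1 oxygen, 2 chlorine; one six-membered aromatic ring of carbon only) in place of a group of 10 heavy atoms (8 carbon, 2 chlorine; one six-membered aromatic ring of carbon only), on a carbonyl carbon. No measured step can be read, so no direction follows from them. Compound 1, which also carries an oxygen-linked group on that carbonyl carbon, gives < 1 ug/mL in this assay. Compound 4 is therefore expected to sit at 0.5 ug/mL, between 0.1 ug/mL and 3 ug/mL, most likely again reported only as a limit. The expected step that the limit leaves unreadable from compound 3 to compound 4 is no larger than the scatter.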

Compound 4, solubility: < 1 ug/mL
Compound 4: no number, only a limit; the forecaster's own chance of this, stated with the estimate: 75%; the middle value is on the limit's open side.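

In this assay compound 4 gives only a limit and not a number, so its steps from compound 1, compound 2 and compound 3 cannot be read: the limit of < 1 ug/mL in this assay, at which 4 of the 4 values shown sit.

The compounds shown leave open whether these groups on the carbonyl carbon differ at all in this assay.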